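A few compounds are considered here, and "the series" means these few. Any claim that something is new, unique, unknown or untested is made for them only; others in the source may bear on it.

Measured in an ADME assay on Caco-2 cells (Homo sapiens) for permeability, read by LC-MS, in the apical to basolateral direction, with a stated time of 60 min, at pH 6.5; a higher number here means that the compound crosses the layer faster, a lower number that the compound crosses the layer more slowly
- Compound 1 `CC(C)(C)OC[C@@H](O)C(=O)N1[C@H](C(=O)NCc2cc(Cl)ccc2-n2cnnn2)C[C@@H]2C[C@@H]21` gives 4.5 10^-6 cm/s
- Compound 2 `O=C(NCc1cc(Cl)ccc1-n1cnnn1)[C@@H]1C[C@@H]2C[C@@H]2N1C(=O)[C@H](O)c1ccccc1F` gives 16 10^-6 cm/s

Compound 2 holds the higher of the two numbers. Compound 3 `COC(C)(C)[C@@H](O)C(=O)N1[C@H](C(=O)NCc2cc(Cl)ccc2-n2cnnn2)C[C@@H]2C[C@@H]21` differs from it as follows: 1-methoxy-1-methylethyl in place of 2-fluorophenyl on a saturated chain carbon bound to a carbonyl carbon and an oxygen on a saturated carbon. This places 1-methoxy-1-methylethyl in place of 2-fluorophenyl on a saturated chain carbon bound to a carbonyl carbon and an oxygen on a saturated carbon. Among the compounds with values here, the one measured step bearing on this is a 3.6-fold higher number from compound 1 to compound 2 (0.55 log units; beyond the scatter), at that same place. Compound 1, whose group likewise has no ring, stands at 4.5 10^-6 cm/s, so a step of similar size downward is expected. The expected step is a 2.9-fold lower number from compound 2 to compound 3 (0.46 log units; beyond the scatter). The estimate for compound 3 is 5.5 10^-6 cm/s, with an expected range from 2.2 10^-6 cm/s to 13 10^-6 cm/s.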

Compound 3, apparent permeability: 16 10^-6 cm/s
Compound 3: middle estimate off by 2.9-fold (0.46 log units), on the low side; measured number outside the range, above it.
By their numbers in this assay, from the lowest: compound 1; then compounds 2 and 3 (each within the scatter of the next).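

In this assay the exchange of 2-fluorophenyl for 1-methoxy-1-methylethyl gives no change at the digits printed from compound 2 to compound 3 (within the scatter), so at this saturated chain carbon the aromatic ring is not needed to keep the number of compound 2. The two ring-free groups do not read alike: 1-methoxy-1-methylethyl in place of (tert-butoxy)methyl gives a 3.6-fold higher number from compound 1 to compound 3 (0.55 log units; beyond the scatter), which leaves compound 1 alone at the low end. No supporting data explain this difference.

Still open, on these data alone, is how an isopropyl group, without the ether oxygen, would read at this place. As far as these compounds go, the effect of an amine or a carboxylic acid here also remains open.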